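This account rests on a few compounds, and the source may have more. Where it says the series, first, only, none or still open, it means among the compounds named here.

Compound 3 `Cn1cnc2c(C#N)nc(-c3ccc(CCO)c(C(F)(F)F)c3)cc21` gives the lowest number of the three in an assay on isolated protein for inhibition of cathepsin S (Homo sapiens), read by fluorescence (a lower number here means a stronger inhibitor, a higher number a weaker inhibitor), with 71 nM. Compound 1 `N#Cc1nc(-c2cccc(C(F)(F)F)c2)cc2[nH]cnc12` gives 1050 nM, and compound 2 `CC(=O)Nc1ccc(-c2cc3[nH]cnc3c(C#N)n2)cc1C(F)(F)F` gives 3240 nM; compound 3 differs from each of them in more than one place, so only the values themselves can be compared, and compound 3 sits well below both.

Compound 4 `CN(C)CCCOc1ccc(-c2cc3c(ncn3C)c(C#N)n2)cc1C(F)(F)F` is the next step from compound 3. The change is 3-(dimethylamino)propoxy in place of 2-hydroxyethyl on an aromatic carbon, at the aromatic carbon ortho to a trifluoromethyl group and para to a large group. Among the compounds with values here, only one measured step bears on this position: a 3.1-fold higher number from compound 1 to compound 2 (0.49 log units; beyond the scatter), where a group was added where before only hydrogen stood. That step went upward in number, and it concerned a different group, so it offers no direct read on swapping one chain for another. Within the data shown here, with nothing closer to lean on, a change of modest size in this assay is expected, more likely upward than downward, as the only step at this position went that way.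

The estimate for compound 4 in this assay is 130 nM, within a range from 35 nM to 500 nM, which is expected to mean a step of a 1.8-fold higher number from compound 3 to compound 4 (0.26 log units; within the scatter).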

Compound 4, half-maximal inhibitory concentration: 41 nM
Beside the measured number, compound 4's estimate is 3.2-fold (0.50 log units) above it; low and high end bracket the measured number.
By their numbers in this assay, from the lowest: compounds 4 and 3 (each within the scatter of the next); then compound 1; then compound 2.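

In this assay, putting 3-(dimethylamino)propoxy in place of 2-hydroxyethyl gives a 1.7-fold lower number from compound 3 to compound 4 (0.24 log units; within the scatter) and so the two compounds cannot be told apart, which makes this the first read on trading one chain for another at this aromatic carbon, ortho to a trifluoromethyl group. The earlier step, a 3.1-fold higher number from compound 1 to compound 2 (0.49 log units; beyond the scatter) when acetamido took the place of hydrogen, said nothing about such a swap, whereas this pair shows that a chain of 7 heavy atoms with 0 hydrogen-bond donors reads the same here as a chain of 3 heavy atoms with 1 hydrogen-bond donor, so for this pair the donor of the 2-hydroxyethyl group is not needed to reach a number of this size. No measurement at hand explains why the two chains read alike.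

The compounds shown cannot say whether the amine at the end of the new chain matters in itself, which a 3-hydroxypropoxy chain at the same carbon would help to test. From the compounds shown here alone, whether a carboxylic acid, a plain methoxy or a longer amine chain there would read the same also stays open.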